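Vero cell tolerance across aryl variants of the shared core

The compounds below may be only part of what the source reports. "The series", "measured", "known", "first", "only" and "open" are said of these compounds alone.

Compound 2 `C[C@]1(CN2CCc3nc(-c4cc(F)cc(F)c4)ccc3C2)Cn2cc([N+](=O)[O-])nc2O1` carries a 3,5-difluorophenyl on the shared core. In an ADME assay on Vero cells (Chlorocebus sabaeus) for cytotoxicity, read by MTT assay, with a stated time of 72 h (a higher number here means that more compound is tolerated, a lower number that less compound is tolerated), compound 2 gives > 32 ug/mL, which is a limit of the assay and not a number. Compound 1 `C[C@]1(CN2CCc3nc(-c4ccc(F)c(F)c4)ccc3C2)Cn2cc([N+](=O)[O-])nc2O1` differs only in bearing a 3,4-difluorophenyl instead. In this assay compound 1 gives > 32 ug/mL, likewise a limit. The step that the two limits leave unreadable from compound 1 to compound 2 cannot be read because of the limit of > 32 ug/mL in this assay, at which 2 of the 2 values shown sit. Among the compounds with values here, compound 2 therefore stands at the same limit as the one other value shown, and no ordering between the two compounds is possible.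

Compound 3 `C[C@]1(CN2CCc3nc(-c4cccc(Cl)c4F)ccc3C2)Cn2cc([N+](=O)[O-])nc2O1` is not yet measured. Relative to compound 2 the change is 3-chloro-2-fluorophenyl in place of 3,5-difluorophenyl on an aromatic carbon. Within the data shown here, the only measured step concerns the substitution pattern of the same aryl group and is unreadable, so no size of step in this assay can be derived from it; the expectation is no change beyond the scatter, with a limit again the most probable outcome. The step that this estimate means is a number no higher from compound 2 to compound 3 (the limit leaves the size open). Compound 3 is estimated at 32 ug/mL, with a range of 16 ug/mL to 64 ug/mL.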

Compound 3, half-maximal cytotoxic concentration: > 32 ug/mL
Compound 3: only a limit was reported; the forecaster's own chance of this, stated with the estimate: 75%; the middle value lies on the limit itself.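

In this assay compound 3 gives > 32 ug/mL, which is a limit of the assay and not a number. No new step can be read between compound 3 and either compound 1 or compound 2, because all three compounds sit at one limit: the limit of > 32 ug/mL in this assay, at which 3 of the 3 values shown sit.

The compounds shown leave open whether these aryl variants differ at all in this assay.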